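This account rests on a few compounds, and the source may have more. Where it says the series, first, only, none or still open, it means among the compounds named here.

Measured so far:
compound 1 `Cc1cc(-c2ccccc2NCC2=NCCN2)on1`: 95.5 nM
compound 2 `Cc1nc(-c2ccccc2NCC2=NCCN2)no1`: 676 nM

Both were tested in a functional assay for activation of Alpha-1B adrenergic receptor (Homo sapiens), read by calcium flux; on this read-out higher numbers stand for an effect only at larger amounts of compound and lower numbers for an effect already at smaller amounts. Compound 1 gives 95.5 nM, and compound 2 gives 676 nM. Going by the values given here, compound 2 therefore holds the higher of the two numbers, and the only measured step, a 7.1-fold higher number from compound 1 to compound 2 (0.85 log units; beyond the scatter), lies beyond the scatter.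

Compound 3 `c1ccc(-c2ccccc2NCC2=NCCN2)nc1` has not been measured. It differs from compound 2 in one place: pyridin-2-yl in place of 5-methyl-1,2,4-oxadiazol-3-yl on an aromatic carbon. Among the compounds with values here, the single step that bears on this change, a 7.1-fold higher number from compound 1 to compound 2 (0.85 log units; beyond the scatter), shows that exchanging the small aromatic ring at this position can move the number well beyond the scatter. Within the data shown here, compound 3 carries a ring unlike either of the measured ones, so no measured step tells the direction directly. For compound 3 the expected step is a 2.7-fold lower number from compound 2 to compound 3 (0.43 log units; beyond the scatter), a move back toward the number of compound 1, since compound 2 already gives the weaker result with 676 nM. Compound 3 is estimated at 250 nM, with a range from 50 nM to 1500 nM.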

Compound 3, half-maximal effective concentration: 30.2 nM
Compound 3: the middle estimate sits 8.3-fold (0.92 log units) above what was measured; measured number below the stated range.
By their numbers in this assay, from the lowest: compound 3; then compound 1; then compound 2.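

In this assay, a six-membered aromatic ring at this position does better than either five-membered ring shown: pyridin-2-yl brings a 22-fold lower number from compound 2 to compound 3 (1.35 log units; beyond the scatter) and also a 3.2-fold lower number from compound 1 to compound 3 (0.50 log units; beyond the scatter), so compound 3 holds the lowest number of the three. The change from 5-methyl-1,2,4-oxadiazol-3-yl to pyridin-2-yl keeps the count of 6 heavy atoms, yet the number still moves by a large step, so the kind of ring matters here and not only that count. No measured evidence on these compounds explains this difference.

The compounds shown leave open whether the ring's nitrogen is needed at all, as a plain phenyl ring would show. From the compounds shown here alone, whether a ring is needed at this position also remains open, and a methoxy group or an amine in its place would test that.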